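Dropping One Fluorine from Compound 1

A few compounds are considered here, and "the series" means these few. Any claim that something is new, unique, unknown or untested is made for them only; others in the source may bear on it.

Compound 1, `COc1cc(C(=O)N/N=C/c2ccc(F)c(F)c2)cc(OC)c1OC`: 51.9%
Compound 2, `COc1cc(C2=NN(C(C)=O)C(c3cccc(OC)c3OC)O2)cc(OC)c1OC`: 17.5%
Compound 3, `COc1ccc(OC)c(/C=N/NC(=O)c2cc(OC)c(OC)c(OC)c2)c1`: 10.1%

Of the compounds shown here, three have been tested in a functional assay on BGC-823 cells (Homo sapiens) for antiproliferative activity, read by MTT assay, tested at 5 uM (on this read-out lower numbers stand for a weaker effect and higher numbers for a stronger effect at the one concentration tested), and compound 1 stands at the top: its number is the highest of the three, and both compound 2 and compound 3 lie beyond the usual scatter below it, with compound 3 the furthest away. Within the data shown here, compound 2 and compound 3 carry different cores, so no single-point step links any pair of measured compounds, and no measured step is available to guide the next move.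

Compound 4, `COc1cc(C(=O)N/N=C/c2ccc(F)cc2)cc(OC)c1OC`, keeps the core of compound 1 and changes only one spot: hydrogen in place of fluoro on an aromatic carbon. One fluorine atom is removed, nothing else moves.

Without a measured step of this kind, the expectation is that the loss of one fluoro costs little in this assay, giving a modest drop in inhibition or none beyond the scatter. Compound 4 is therefore expected to show about 42%, with a plausible range from 25% to 58%. The step of a number 9.9 percentage points lower from compound 1 to compound 4 (within the scatter) is the estimated size of that change.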

Compound 4, a percentage reported as inhibition, at one concentration (the size of the read-out at that concentration, not a potency): 61.1%
For compound 4 the middle estimate is 19.1 percentage points below the measured one; the measured number lies above the stated range.
By their numbers in this assay, from the lowest: compounds 3 and 2 (each within the scatter of the next); then compounds 1 and 4 (each within the scatter of the next).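

Among these compounds, replacing the fluoro with hydrogen, which turns the 3,4-difluorophenyl group into 4-fluorophenyl, gives the first single-place comparison in this assay: a number 9.2 percentage points higher from compound 1 to compound 4 (within the scatter). At this position, then, the fluoro group ortho to the remaining fluoro is not needed to keep the inhibition seen at the one concentration tested, since compound 4 and compound 1 cannot be told apart on this read-out. Nothing available explains this outcome.

As far as these compounds go, whether this aromatic carbon would accept something other than hydrogen or fluoro, such as chloro, a hydroxyl or an amine, remains open. So does the role of the remaining fluoro group, and a single concentration cannot show whether compound 4 and compound 1 would also match in potency.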